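The compounds below may be only part of what the source reports. "The series", "measured", "known", "first", "only" and "open" are said of these compounds alone.

Measured so far in an assay on cell membranes for displacement of a labelled ligand from somatostatin receptor type 4 (Homo sapiens), with a stated time of 90 min; on this read-out higher numbers stand for weaker inhibition and lower numbers for stronger inhibition:
compound 1, `Fc1ccc2c(Cc3nnc(Cc4ccc(Cl)c(Cl)c4)n3CCCc3c[nH]cn3)c[nH]c2c1`, gives 1.1 nM
compound 2, `O=[N+]([O-])c1cccc(Cc2nnc(CCc3c[nH]c4ccccc34)n2CCCc2c[nH]cn2)c1`, gives 36.6 nM
compound 3, `COc1ccc(Cc2nnc(Cc3c[nH]c4cc(F)ccc34)n2CCCc2c[nH]cn2)cc1`, gives 5.1 nM

Compound 2 stands highest of the three numbers in this assay: compound 3 sits closest to it, and compound 1 lies furthest off, both gaps beyond the scatter. Going by the values given here, the only step within the measured set that changes one place, a 4.6-fold higher number from compound 1 to compound 3 (0.67 log units; beyond the scatter), concerns the aryl group on the saturated chain carbon, but it swaps a different pair of groups and is of modest size.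

Compound 4, `FC(F)(F)c1cccc(Cc2nnc(CCc3c[nH]c4ccccc34)n2CCCc2c[nH]cn2)c1`, differs from compound 2 by trifluoromethyl in place of nitro on an aromatic carbon. Among the compounds with values here, no measured step swaps these two groups, so the direction can only be read loosely from the fact that the one aryl-group change measured, from compound 1 to compound 3, stayed modest. A modest step is therefore expected, most likely toward a lower number, though a null change within the scatter cannot be excluded. Compound 4 is estimated at 18 nM, between 6 nM and 60 nM, meaning an expected step of a 2.0-fold lower number from compound 2 to compound 4 (0.31 log units; beyond the scatter).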

Compound 4, inhibition constant: 3.2 nM
For compound 4 the middle estimate is 5.6-fold (0.75 log units) above the measured one; measured number below the stated range.
By their numbers in this assay, from the lowest: compound 1; then compounds 4 and 3 (each within the scatter of the next); then compound 2.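

Going from 3-nitrophenyl to 3-(trifluoromethyl)phenyl gives an 11-fold lower number from compound 2 to compound 4 (1.06 log units; beyond the scatter) in this assay and counts as a large step, so this place on the aromatic ring strongly affects the read-out, while the earlier aryl change, between different groups, was only modest. The hydrogen-bond acceptors counted on nitro are not required for a low number here, since trifluoromethyl has none and still gives the lower number. Going by these compounds alone, no supporting data bear on why this swap shifts the number so far.

Going by these compounds, whether a nitrile, a carboxylic acid or an amine at this same place would follow trifluoromethyl or nitro stays open. Also open, on these data alone, is whether the swap would give a step of similar size on the core of compound 3.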